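The source may hold more compounds than are shown below. What is called first, only, known or untested is meant among the compounds shown, and "the series" means these compounds.

Among the measured compounds shown here, compound 1 `CC1CCN(C2CCN(S(=O)(=O)c3ccc(-c4ccccc4)cc3)CC2)CC1` gives 258 nM in a functional assay on DLD-1 cells (Homo sapiens) for antiproliferative activity, read by CellTiter-Glo, with a stated time of 72 h (on this read-out lower numbers stand for stronger inhibition and higher numbers for weaker inhibition), the higher of the two numbers measured so far. Compound 2 `Cc1cc(C)cc(-c2cccc(S(=O)(=O)N3CCC(N4CCC(C)CC4)CC3)c2)c1` gives 41 nM in this assay, a gap from compound 1 that lies beyond the scatter. Compound 3 `COC(=O)c1ccc(S(=O)(=O)N2CCC(N3CCC(C)CC3)CC2)cc1` differs from compound 1 by methoxycarbonyl in place of phenyl on an aromatic carbon. For the measured compounds named here, no measured pair differs in this one place. The size of this step is therefore open. Expected for it: weaker inhibition in this assay, a step of about a 4.7-fold higher number from compound 1 to compound 3 (0.67 log units; beyond the scatter), probably beyond the scatter but with wide uncertainty. For compound 3 the estimate in this assay is 1200 nM, with a range from 300 nM to 5000 nM.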

Compound 3, half-maximal inhibitory concentration: > 5000 nM
Compound 3 ended at the assay's limit; the forecaster's own chance of this, stated with the estimate: 15%; at least 4.1-fold (0.61 log units) between middle value and limit.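

In this assay compound 3 gives > 5000 nM, which is a limit of the assay and not a number. On this aromatic carbon, para to a large group, methoxycarbonyl in place of phenyl gives an at least 19-fold higher number from compound 1 to compound 3 (1.28 log units; beyond the scatter), so antiproliferative activity in this pair depends strongly on what this position carries. The step is a lower bound only: the limit of > 5000 nM in this assay, at which 1 of the 3 values shown sits.

As far as these compounds go, whether the weakening tracks the loss of the aromatic ring or the entry of the ester stays open. From the compounds shown here alone, how a pyridyl ring, a primary amide or a carboxylic acid on this carbon would read also remains open.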